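The source may hold more compounds than are shown below. What is called first, only, known or untested is meant among the compounds shown, and "the series" means these compounds.

Among the measured compounds shown here, in an ADME assay on L6 cells (Rattus norvegicus) for cytotoxicity, read by fluorescence and resazurin assay, with a stated time of 72 h (on this read-out higher numbers stand for weaker inhibition and lower numbers for stronger inhibition), compound 2 (`CC(=O)[C@@]1(Cc2ccc(C)cc2)CC[C@]2(C)OO[C@@]1(C)O2`) gives 15300 nM, the higher of the two numbers so far. Compound 1 (`CC(=O)CCC1(Cc2ccc(Br)cc2)[C@]2(C)OO[C@@]1(C)OO2`) gives 2500 nM. The gap between these two values lies beyond the scatter. Compound 3 (`CC(=O)[C@@]1(Cc2ccc(Br)cc2)CC[C@]2(C)OO[C@@]1(C)O2`) changes compound 2 in one place: bromo in place of methyl on an aromatic carbon, turning 4-methylphenyl into 4-bromophenyl. Compound 1, at 2500 nM, also carries 4-bromophenyl, but on a different core, so it offers only weak guidance. In this assay a small move toward a lower number is expected, possibly within the scatter, with the estimated step of a 1.7-fold lower number from compound 2 to compound 3 (0.23 log units; within the scatter). The estimate for compound 3 is 9000 nM, with an expected range of 3500 nM to 20000 nM.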

Compound 3, half-maximal inhibitory concentration: 8100 nM
Beside the measured number, compound 3's estimate is 1.1-fold (0.05 log units) above it; measured number inside the range.
By their numbers in this assay, from the lowest: compound 1; then compounds 3 and 2 (each within the scatter of the next).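

In this assay, bromo in place of methyl on an aromatic carbon, para to a large group, gives a 1.9-fold lower number from compound 2 to compound 3 (0.28 log units; within the scatter), so on this shared core the swap stays within the scatter. Among the compounds shown here, this is the only one-place comparison so far, so it speaks for these two groups on this core alone. No evidence on hand accounts for the result. The compounds shown leave open how an amine or a carboxylic acid on that same aromatic carbon would read.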